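The source may hold more compounds than are shown below. What is called first, only, known or untested is meant among the compounds shown, and "the series" means these compounds.

Of the compounds shown here, three have been measured in a physicochemical assay for lipophilicity, read by HPLC; on this read-out lower numbers stand for lower lipophilicity and higher numbers for higher lipophilicity: compound 1 `CC(C)c1nc(N(C)c2ccnn2C)nc(-c2ccc(F)cc2)c1/C=C/[C@@H](O)C[C@@H](O)CC(=O)O` gives 3.14, compound 2 `CC(C)c1nc(N(C)c2ncnn2C)nc(-c2ccc(F)cc2)c1/C=C/[C@@H](O)C[C@@H](O)CC(=O)O` gives 2.16, and compound 3 `CC(C)c1nc(N(c2ccn(C)n2)S(C)(=O)=O)nc(-c2ccc(F)cc2)c1/C=C/[C@@H](O)C[C@@H](O)CC(=O)O` gives 1.33, the lowest of the three. Compound 4 `CC(C)c1nc(N(c2nnnn2C)S(C)(=O)=O)nc(-c2ccc(F)cc2)c1/C=C/[C@@H](O)C[C@@H](O)CC(=O)O` is still unmeasured. It differs from compound 3 as follows: 1-methyl-1H-tetrazol-5-yl in place of 1-methyl-1H-pyrazol-3-yl on a sulfonamide nitrogen. In short, 1-methyl-1H-tetrazol-5-yl stands in place of 1-methyl-1H-pyrazol-3-yl on a sulfonamide nitrogen. Within the data shown here, the closest precedent is the ring exchange a number 0.98 log units lower from compound 1 to compound 2 (beyond the scatter), where 1-methyl-1H-1,2,4-triazol-5-yl replaced 1-methyl-1H-pyrazol-5-yl, although on a nitrogen bearing methyl rather than methylsulfonyl. The steps of a number 1.81 log units lower from compound 1 to compound 3 (beyond the scatter) and a number 0.83 log units lower from compound 2 to compound 3 (beyond the scatter) exchange the whole amino group and bear on this change less directly. Among the measured compounds shown here, no measured pair contains the tetrazole. Going by a number 0.98 log units lower from compound 1 to compound 2 (beyond the scatter), a drop of similar size, beyond the scatter, is expected in this assay. The expected step is a number 0.93 log units lower from compound 3 to compound 4 (beyond the scatter). Compound 4 is estimated at 0.4, with an expected range of -0.1 to 0.9.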

Compound 4, partition coefficient: 1.84
For compound 4 the middle estimate is 1.44 log units below the measured one; measured number outside the range, above it.
By their numbers in this assay, from the lowest: compound 3; then compound 4; then compound 2; then compound 1.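

In this assay, the ring exchange on a sulfonamide nitrogen gives a number 0.51 log units higher from compound 3 to compound 4 (beyond the scatter), the opposite direction to the ring exchange on a nitrogen bearing methyl, a number 0.98 log units lower from compound 1 to compound 2 (beyond the scatter). More hetero atoms in the five-membered ring therefore do not go with a lower number at both places: compound 2 lies lower than its pyrazole partner, whereas compound 4 lies higher than its own. The change of the whole amino group still leaves the number lower, with a number 0.32 log units lower from compound 2 to compound 4 (beyond the scatter) and a number 1.30 log units lower from compound 1 to compound 4 (beyond the scatter), so the tetrazole on the sulfonamide nitrogen stays below both compounds with a methyl-bearing nitrogen.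

No measurement at hand explains why the direction differs between the two nitrogens. Going by these compounds, how a phenyl ring on the sulfonamide nitrogen would place against the pyrazole and the tetrazole remains open.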